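A few compounds are considered here, and "the series" means these few. Any claim that something is new, unique, unknown or untested is made for them only; others in the source may bear on it.

In a functional assay on OVCAR-5 cells (Homo sapiens) for cytotoxicity, read by sulforhodamine B assay, with a stated time of 48 h, tested at 0.01 uM (a higher number here means a weaker effect of the compound at the concentration tested, a lower number a stronger effect), the measured compounds stand as follows:
compound 1, `COc1cc(C)cc(-c2c(-c3ccnc(-c4ccc(C(C)=O)cc4)c3)cnn2CC#N)c1`: 70%
compound 2, `Cc1cc(O)cc(-c2nn(CC#N)cc2-c2ccnc(-c3ccc(Oc4ccccc4)cc3)c2)c1`: 72%
compound 3, `COc1cc(C)cc(-c2nn(CC#N)cc2-c2ccnc(-c3ccc(N(C)C)cc3)c2)c1`: 93%

Compound 3 holds the highest of the three numbers; compound 2 lies nearest to it, with a number lower beyond the scatter, and compound 1 lies furthest, again beyond the scatter. Going by the values given here, no two of these three compounds differ in one place only, so no single step has been measured among them. Compound 4, `Cc1cc(O)cc(-c2nn(CC#N)cc2-c2ccnc(-c3ccc(N(C)C)cc3)c2)c1`, is still to be measured in this assay. It differs from compound 3 thus: hydrogen in place of methyl on an oxygen on an aromatic ring. Among the compounds with values here, with no measured step for this change, only a small fall in the number is expected, a number 8 percentage points lower from compound 3 to compound 4 (within the scatter), probably not clearly beyond the scatter. For compound 4 the estimate is 85%, within 65% to 100%.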

Compound 4, a percentage reported as activity, at one concentration (the size of the read-out at that concentration, not a potency): 91%
Beside the measured number, compound 4's estimate is 6 percentage points below it; measured number inside the range.
By their numbers in this assay, from the lowest: compounds 1 and 2 (each within the scatter of the next); then compounds 4 and 3 (each within the scatter of the next).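

In this assay, a number 2 percentage points lower from compound 3 to compound 4 (within the scatter), so with dimethylamino held constant, methoxy to hydroxy on this oxygen on an aromatic ring does not separate the two compounds. Going by these compounds alone, by contrast, a number 19 percentage points higher from compound 2 to compound 4 (beyond the scatter), a modest change and the first single change here to pass the scatter, with dimethylamino in place of phenoxy on an aromatic carbon. No supporting data explain either step. On these data alone, whether methoxy to hydroxy stays this small with phenoxy in place remains open. So does how a longer chain on that oxygen, or a carboxylic acid in place of dimethylamino, would read.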